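Working notes on four compounds in a cytotoxicity assay

This account rests on a few compounds, and the source may have more. Where it says the series, first, only, none or still open, it means among the compounds named here.

Compound 1 `COc1cc(/C=C/C(=O)c2sc(Nc3cccc(Cl)c3)nc2C)cc(OC)c1OC`: in a functional assay on NCI-H460 cells (Homo sapiens) for cytotoxicity, read by MTT assay (on this read-out higher numbers stand for weaker inhibition and lower numbers for stronger inhibition), compound 1 gives only the limit > 25000 nM.
Compound 2 `COc1cccc(/C=C/C(=O)c2sc(Nc3ccccc3C)nc2C)c1`: in this assay compound 2 gives only the limit > 25000 nM.
Compound 3 `COc1cc(/C=C/C(=O)c2sc(Nc3ccccc3C)nc2C)cc(OC)c1OC`: in this assay compound 3 gives 6320 nM.

Compound 4 `COc1cccc(/C=C/C(=O)c2sc(Nc3cccc(Cl)c3)nc2C)c1` is not yet measured. The difference between the cores of compound 2 and compound 3 is not broken down here. The change from compound 3 to compound 1, (3-chlorophenyl in place of 2-methylphenyl on a nitrogen on an aromatic ring), is the same as that from compound 2 to compound 4, (3-chlorophenyl in place of 2-methylphenyl on a nitrogen on an aromatic ring), and the two places read alike word for word. Measured once, the change gave an at least 3.9-fold higher number from compound 3 to compound 1 (0.59 log units; beyond the scatter), a step that rests on (the limit of > 25000 nM in this assay, at which 2 of the 3 values shown sit). Compound 2 already sits at that limit, so the same change is expected to leave compound 4 at the limit as well. The expected step is a step that the limit leaves unreadable from compound 2 to compound 4. For compound 4 the estimate is 60000 nM, with a range from 25000 nM to 250000 nM, and most likely only a limit will be reported.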

Compound 4, half-maximal inhibitory concentration: > 25000 nM
Compound 4 gave a limit, no number (the forecaster's own chance of this, stated with the estimate: 85%); the middle value lies beyond the limit too.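

Compound 2 and compound 4 both give only a limit in this assay, so no new step can be read between them: the limit of > 25000 nM in this assay, at which 3 of the 4 values shown sit.
On these data alone, how far compound 1, compound 2 and compound 4 lie past that limit remains open.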